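A hydroxyphenyl-to-dichlorophenyl swap repeated on a second core

The compounds below may be only part of what the source reports. "The series", "measured", "known", "first", "only" and "open" are said of these compounds alone.

Compound 1 `COc1cccc(/C=C2\CCC/C(=C\c3ccc(O)cc3)C2=O)c1OC` and compound 3 `COc1ccc(/C=C2\CCC/C(=C\c3ccc(O)cc3)C2=O)cc1OC` are built from the same atoms joined differently; the difference between their two cores is not broken down here. In a functional assay on HT-1080 cells (Homo sapiens) for cytotoxicity, read by MTT assay, with a stated time of 72 h (on this read-out lower numbers stand for stronger inhibition and higher numbers for weaker inhibition), compound 1 gives > 20000 nM, which is the limit of > 20000 nM in this assay, at which 1 of the 3 values shown sits, rather than a measured number. In this assay compound 3 gives 16800 nM. Compound 2 `COc1cccc(/C=C2\CCC/C(=C\c3cccc(Cl)c3Cl)C2=O)c1OC` carries 2,3-dichlorophenyl in place of 4-hydroxyphenyl on a double-bonded chain carbon bound to a double-bonded ring carbon, and in this assay compound 2 gives 19300 nM, so that an at least 1.0-fold lower number from compound 1 to compound 2 (0.01 log units; that floor lies within the scatter). Compound 4 `COc1ccc(/C=C2\CCC/C(=C\c3cccc(Cl)c3Cl)C2=O)cc1OC` carries the same change on the core of compound 3, namely (2,3-dichlorophenyl in place of 4-hydroxyphenyl on a double-bonded chain carbon bound to a double-bonded ring carbon). Given that the earlier change gave only the floor an at least 1.0-fold lower number from compound 1 to compound 2 (0.01 log units; that floor lies within the scatter), the step from compound 3 to compound 4 is expected to be a 1.2-fold lower number from compound 3 to compound 4 (0.08 log units; within the scatter). Compound 4 is therefore expected to give 14000 nM in this assay.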

Compound 4, half-maximal inhibitory concentration: 8800 nM
The estimate for compound 4 lay 1.6-fold (0.20 log units) above the measured number; the range from low to high includes it.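

In this assay, 2,3-dichlorophenyl in place of 4-hydroxyphenyl gives a 1.9-fold lower number from compound 3 to compound 4 (0.28 log units; within the scatter). Set beside the same change on the other core, the comparison stays unsettled: the same change on two cores in this assay, an at least 1.0-fold lower number (0.01 log units; that floor lies within the scatter) from compound 1 to compound 2 and a 1.9-fold lower number (0.28 log units; within the scatter) from compound 3 to compound 4; the limit leaves it open whether they differ

From the compounds shown here alone, compound 1 gives > 20000 nM, which is a limit and not a number, so the true size of the first step is unknown, and the two steps show neither that the change carries over between these cores nor that it does not.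

The compounds shown leave open whether another group on the same double-bonded chain carbon, such as a phenyl ring carrying an amine or a carboxylic acid, would shift the number beyond the scatter. With only two cores shown, how the change behaves on any other core also stays open.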